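Sulfamoyl in Place of Fluoro: An Expected Value

This account rests on a few compounds, and the source may have more. Where it says the series, first, only, none or still open, it means among the compounds named here.

Within the data shown here, compound 1 `N#CC1CN1C(=O)Nc1ccc(F)cc1` holds the lowest of the two numbers measured so far. In a functional assay on OVCAR-3 cells (Homo sapiens) for inhibition (a lower number here means a stronger inhibitor, a higher number a weaker inhibitor), compound 1 gives 5900 nM. Compound 2 `CCNC(=O)N1CC1C#N` is its nearest neighbour, and in this assay compound 2 gives 14000 nM, a higher number that lies beyond the usual scatter, so compound 1 is the stronger inhibitor of the pair. Among the measured compounds shown here, no two measured compounds differ in a single place, so no step of known size connects them. The unmeasured compound 3 `N#CC1CN1C(=O)Nc1ccc(S(N)(=O)=O)cc1` differs from compound 1 by sulfamoyl in place of fluoro on an aromatic carbon. For the measured compounds named here, nothing among the measured compounds shows what a change of this kind does in this assay, and the expectation therefore leans on the value of compound 1 alone, which is 5900 nM. Compound 3 is expected to stay close to that value, with no step beyond the scatter in either direction. The estimated step is a 1.0-fold higher number from compound 1 to compound 3 (0.01 log units; within the scatter). In this assay compound 3 is thus expected to give 6000 nM, in a range from 1500 nM to 24000 nM.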

Compound 3, half-maximal inhibitory concentration: 188000 nM
Compound 3: middle estimate off by 31-fold (1.50 log units), on the low side; measured number outside the range, above it.
By their numbers in this assay, from the lowest: compound 1; then compound 2; then compound 3.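

In this assay, among these compounds, sulfamoyl in place of fluoro on this aromatic carbon gives the first single-place change that can be read, and it brings a 32-fold higher number from compound 1 to compound 3 (1.50 log units; beyond the scatter), a large step toward weaker inhibition. The position is therefore far from indifferent to what it carries: with the rest of the core of compound 1 unchanged, this one exchange on the carbon para to the group of 8 heavy atoms moves the number well beyond the scatter. Nothing measured here identifies which feature of the sulfamoyl group goes with this weakening.

With only this one exchange at the position, the compounds shown leave open whether the weakening belongs to sulfamoyl in particular or would follow from other replacements of fluoro, such as hydrogen, chloro, methyl, an amine or a carboxylic acid. They also leave open whether a methylsulfonyl group, which keeps the sulfur and its two oxygens but lacks the nitrogen, or a sulfamoyl group carrying a methyl on its nitrogen would behave as compound 3 does.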